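The source may report more compounds than this note shows. Statements on the series, on what has been measured and on what is new or still open speak of the compounds shown alone.

Measured so far in an ADME assay on S9 fraction from liver (Homo sapiens) for metabolic stability, with a stated time of 1 h (a higher number here means that more of the compound is left, a lower number that less of the compound is left), are two compounds:
- compound 1 `CO[C@H]1CC[C@@H](CNc2cc(NCc3cnccc3C(F)(F)F)ncc2C#N)CC1` with 4% remaining
- compound 2 `N#Cc1cnc(NCc2cncnc2C(F)(F)F)cc1N[C@H]1CC[C@@H](O)CC1` with 76% remaining

Compound 2 holds the higher of these two numbers, and its gap to compound 1 lies well beyond the usual scatter of repeated measurements.

Compound 3 `N#Cc1cnc(NCc2cncnc2OCC(F)F)cc1N[C@H]1CC[C@@H](O)CC1` keeps the rest of compound 2 and makes one change 2,2-difluoroethoxy in place of trifluoromethyl on an aromatic carbon on an aromatic carbon next to the ring nitrogen, with 2,2-difluoroethoxy in place of trifluoromethyl. For the measured compounds named here, no measured pair of compounds isolates this swap. Going by the values given here, the two compounds measured so far differ in more than one place. Any expectation is therefore rough.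

A fall is the likelier direction. Compound 2 at 76% sits high on the scale, with more room below than above, and compound 1 at 4% shows that much lower numbers occur. The estimated step is a number 18 percentage points lower from compound 2 to compound 3 (beyond the scatter) in this assay and so a moderate fall, just beyond the scatter. Compound 3 is estimated at 58% with an expected range from 30% to 82% (an expectation, not yet a measurement).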

Compound 3, percent of the compound remaining: 87%
Beside the measured number, compound 3's estimate is 29 percentage points below it; measured number outside the range, above it.
By their numbers in this assay, from the lowest: compound 1; then compound 2; then compound 3.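

For the compounds shown here, this is the first pair of compounds that isolates a single change at this position, on an aromatic carbon next to the ring nitrogen: in this assay, 2,2-difluoroethoxy in place of trifluoromethyl gives a number 11 percentage points higher from compound 2 to compound 3 (beyond the scatter), a modest step. On this core, then, trifluoromethyl is not required for a high number, and a group with 5 heavy atoms in place of 4, including an oxygen that counts as a hydrogen-bond acceptor, leaves more of the compound remaining. Nothing measured here explains why the number moves this way.

The compounds shown leave open whether the same swap would also raise the number on the core of compound 1, which differs from compound 2 in more than one place. They also leave open how other groups at this position would behave: an ethoxy group, with the oxygen but no fluorine, would help separate the part played by each, while an amine or a longer fluorinated chain would show how much variation this position accepts.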